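Cyclic sulfonate series: cytotoxicity in HEL cells

This account rests on a few compounds, and the source may have more. Where it says the series, first, only, none or still open, it means among the compounds named here.

Working notes on a small set of cyclic sulfonates. Compound 1 `CCC1(Cc2ccccc2)OS(=O)(=O)CC1=O` carries a saturated ring with a ketone; compound 2 `CCC1(Cc2ccccc2)OS(=O)(=O)C=C1OCc1ccc(OC)cc1` and compound 3 `CC(C)C1(Cc2ccccc2)OS(=O)(=O)C=C1OCc1ccccc1` carry an unsaturated ring bearing a benzyloxy-type ether, with a methoxy group on that aryl ring in compound 2 and an isopropyl in place of ethyl in compound 3.

The only read-out is an ADME assay on HEL cells (Homo sapiens) for cytotoxicity, with a stated time of 3 days; a lower number here means that less compound is tolerated, a higher number that more compound is tolerated. In this assay compound 1 gives > 100000 nM, which is a limit of the assay and not a number. Compound 2 gives >= 200000 nM in this assay, again a limit. Compound 3 gives >= 80000 nM in this assay, also a limit. Thus compound 2 stands, like the other two, at a limit: the three values shown give no order among the compounds, only that none was cytotoxic within the tested range (the limit of > 100000 nM in this assay, at which 1 of the 3 values shown sits, (the limit of >= 200000 nM in this assay, at which 1 of the 3 values shown sits), (the limit of >= 80000 nM in this assay, at which 1 of the 3 values shown sits)).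

Compound 4 `CCC1(Cc2ccccc2)OS(=O)(=O)C=C1OCc1ccc(C)cc1` is not yet measured. It differs from compound 2 by methyl in place of methoxy on an aromatic carbon. Within the data shown here, with every value so far sitting at a limit, the step of a number no higher from compound 2 to compound 4 (the limit leaves the size open) is expected to be none beyond the scatter. Compound 4 is therefore expected to give about 200000 nM in this assay, with a range from 80000 nM to 400000 nM, most likely reported as a limit again.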

Compound 4, minimum cytotoxic concentration: >= 16000 nM
Compound 4: only a limit was reported; the forecaster's own chance of this, stated with the estimate: 85%; the middle value does not contradict the limit.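

Among these compounds, compound 2 and compound 4 both stand at limits of the assay, not at numbers, and no step between them can be read for methyl in place of methoxy. The compounds shown leave open at what concentration any of them becomes cytotoxic, and whether going from 4-methoxyphenyl to 4-methylphenyl changes that concentration at all.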